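From 4-cyanobenzyl to 3-chlorobenzyl: working notes on the series

The source may report more compounds than this note shows. Statements on the series, on what has been measured and on what is new or still open speak of the compounds shown alone.

Of the compounds shown here, two have been measured in a functional assay on A-375 cells (Homo sapiens) for antiproliferative activity, read by MTT assay, with a stated time of 24 h; on this read-out higher numbers stand for weaker inhibition and lower numbers for stronger inhibition. Compound 1 `C#CCOc1ccc2c(=O)c(-c3cc(OC)c(OC)cc3OC)coc2c1` gives 3680 nM, and compound 2 `COc1cc(OC)c(-c2coc3cc(OCc4ccc(C#N)cc4)ccc3c2=O)cc1OC` gives 1550 nM, the lower of the two numbers. Among the compounds with values here, the only measured step, a 2.4-fold lower number from compound 1 to compound 2 (0.38 log units; beyond the scatter), is modest but beyond the scatter.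

Next in line is compound 3 `COc1cc(OC)c(-c2coc3cc(OCc4cccc(Cl)c4)ccc3c2=O)cc1OC`, which awaits measurement in this assay. The change is 3-chlorophenyl in place of 4-cyanophenyl on a saturated chain carbon bound to an oxygen on an aromatic ring. Cut one bond further out, it reads 4-cyanobenzyl to 3-chlorobenzyl.

Within the data shown here, the single measured step touches the same place but replaces ethynyl, so it sets a scale only. Among the measured compounds shown here, no measured pair exchanges one substituted phenyl for another, and the direction therefore stays open. A change smaller than that step is expected, with no firm shift beyond the scatter. The estimated step is a 1.2-fold higher number from compound 2 to compound 3 (0.06 log units; within the scatter). For compound 3 the expected value is 1800 nM, within an estimated range of 700 nM to 4500 nM.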

Compound 3, half-maximal inhibitory concentration: 980 nM
Compound 3: the middle estimate sits 1.8-fold (0.26 log units) above what was measured; the measured number falls inside the stated range.
By their numbers in this assay, from the lowest: compounds 3 and 2 (each within the scatter of the next); then compound 1.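

In this assay, the exchange of one substituted phenyl for another on a saturated chain carbon bound to an oxygen on an aromatic ring now has a measured size: a 1.6-fold lower number from compound 2 to compound 3 (0.20 log units; within the scatter), so this pair does not separate 4-cyanobenzyl from 3-chlorobenzyl. Against ethynyl at the same place, 3-chlorophenyl gives a 3.8-fold lower number from compound 1 to compound 3 (0.57 log units; beyond the scatter), and with a 2.4-fold lower number from compound 1 to compound 2 (0.38 log units; beyond the scatter) both substituted phenyl groups shown here now read beyond the scatter from compound 1, with neither compound going against this. No accompanying data bear on the reasons behind these numbers.

Compound 2 and compound 3 differ both in the substituent and in where it sits on the phenyl, so the shown compounds cannot assign the outcome to either change alone, and 4-chlorobenzyl would be the group that separates them. From the compounds shown here alone, the reading of an unsubstituted benzyl, of a phenyl carrying an amine or a carboxylic acid, and of a longer chain between the oxygen and the phenyl remains open.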